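The compounds below may be only part of what the source reports. "The series", "measured", "known", "first", "only" and "open" are said of these compounds alone.

Of the compounds shown here, two with the same atoms and bonds have been measured in a functional assay on KB cells (Homo sapiens) for cytotoxicity, read by colorimetric assay and neutral red uptake, with a stated time of 72 h; on this read-out lower numbers stand for stronger inhibition and higher numbers for weaker inhibition. There, compound 1 (`CO[C@@H](C(=O)N[C@H]1CC[C@@H](O)CNC1=O)[C@H](O)[C@@H](O)[C@H](O)/C=C/C(C)(C)C`) gives 62600 nM and compound 2 (`CO[C@@H](C(=O)N[C@@H]1CC[C@@H](O)CNC1=O)[C@H](O)[C@@H](O)[C@H](O)/C=C/C(C)(C)C`) gives 5100 nM, the lower of the two numbers. The measured change is large, a 12-fold lower number from compound 1 to compound 2 (1.09 log units; beyond the scatter), and it can be traced to configuration alone due to the fact that compounds 1 and 2 differ only in the configuration as drawn.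

Compound 3 (`CO[C@@H](C(=O)N[C@@H]1CC[C@H](O)CNC1=O)[C@H](O)[C@@H](O)[C@H](O)/C=C/C(C)(C)C`) is the next step from compound 2: the two compounds have the same atoms and bonds and differ only in configuration as drawn: 1 of 7 stereo elements differ; a stereocentre at a saturated ring carbon is drawn R in compound 2 and S in compound 3. Nothing leaves and nothing enters, so only the drawn configuration at a saturated ring carbon changes. Among the measured compounds shown here, the only measured guide is the single step of this kind, a 12-fold lower number from compound 1 to compound 2 (1.09 log units; beyond the scatter), which shows that one such change can move the number well beyond the scatter in this assay. For the measured compounds named here, one step cannot fix the direction of another, but compound 2 holds the lower number so far, so a moderately higher number is the more likely outcome. The expected step is a 2.4-fold higher number from compound 2 to compound 3 (0.37 log units; beyond the scatter), smaller than the measured one. For compound 3 the estimated value is 12000 nM, with an expected range from 2500 nM to 50000 nM.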

Compound 3, half-maximal inhibitory concentration: 23700 nM
For compound 3 the middle estimate is 2.0-fold (0.30 log units) below the measured one, within the range that was stated.
By their numbers in this assay, from the lowest: compound 2; then compound 3; then compound 1.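

Compound 3 shows that in this assay a second stereocentre at a saturated ring carbon, distinct from the one changed in a 12-fold lower number from compound 1 to compound 2 (1.09 log units; beyond the scatter), can also move the number beyond the scatter, here with a 4.6-fold higher number from compound 2 to compound 3 (0.67 log units; beyond the scatter), a modest step where the earlier one is large. Compound 2 now holds the lowest number of the three, and its steps to both other compounds lie beyond the scatter, so each of the two single changes of configuration shown leads away from it to a higher number. Compounds 1 and 3 differ at both stereocentres, and a 2.6-fold lower number from compound 1 to compound 3 (0.42 log units; beyond the scatter) cannot be divided between the two, although the difference still comes down to configuration alone: the fact that compounds 1 and 3 differ only in the configuration as drawn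

The compounds shown leave open the number for the fourth combination of these two ring stereocentres, and whether the effect of one centre depends on the configuration of the other. They also leave open whether the configuration of compound 2 would keep its lead with an amine or a methoxy group on the ring in place of the hydroxyl group.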